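Swapping Azide for a Carbamate on the Sugar Ring

The source may hold more compounds than are shown below. What is called first, only, known or untested is meant among the compounds shown, and "the series" means these compounds.

Three compounds were tested in a functional assay on A549 cells (Homo sapiens) for cytotoxicity, read by resazurin assay, with a stated time of 48 h; on this read-out lower numbers stand for stronger inhibition and higher numbers for weaker inhibition. Compound 1 `C=CCOC(=O)NC[C@H]1OC(N(CC2=CC[C@@H](C(=C)C)CC2)OC)[C@H](O)[C@@H](O)[C@@H]1O` gives 140000 nM, and compound 3 `C=C(C)[C@@H]1CC=C(CN(OC)C2OC[C@@H](N=[N+]=[N-])[C@H](O)[C@H]2O)CC1` gives 76000 nM. Compound 2 `C=C(C)[C@@H]1CC=C(CN(OC)C2O[C@H](CO)[C@@H](O)[C@H](O)[C@H]2N=[N+]=[N-])CC1` gives 221000 nM, the highest of the three numbers: it sits within the scatter of compound 1 and beyond the scatter relative to compound 3. Compound 4 `C=CCOC(=O)N[C@H]1C(N(CC2=CC[C@@H](C(=C)C)CC2)OC)O[C@H](CO)[C@@H](O)[C@@H]1O` differs from compound 2 in one place: (allyloxycarbonyl)amino in place of azido on a saturated ring carbon. Within the data shown here, no pair of measured compounds shares this change, so the expectation rests on the spread of the numbers seen. Compound 1 also carries an (allyloxycarbonyl)amino group and gives 140000 nM, within the scatter of compound 2. Compound 4 is therefore expected to stay weak, with a step of a 1.4-fold lower number from compound 2 to compound 4 (0.14 log units; within the scatter) expected to lie within the scatter. Compound 4 is estimated at 160000 nM, ranging from 60000 nM to 400000 nM.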

Compound 4, half-maximal inhibitory concentration: 114000 nM
The estimate for compound 4 lay 1.4-fold (0.15 log units) above the measured number; the measured number falls inside the stated range.
By their numbers in this assay, from the lowest: compounds 3, 4, 1 and 2 (each within the scatter of the next, the first and the last beyond it).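

In this assay, (allyloxycarbonyl)amino in place of azido on this saturated ring carbon gives a 1.9-fold lower number from compound 2 to compound 4 (0.29 log units; within the scatter). The earlier compounds shown here offered no matched pair for this change, and this pair shows that the larger group, with its added hydrogen-bond donor, leaves the number within the scatter at this position. Nothing measured here bears on the reason for this result. Still open, on these data alone, is whether a free amine or an acetamido group on the same ring carbon would also stay within the scatter of compound 2.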